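Removing the phenethyl arm from cyanoguanidine histamine antagonists

The source may hold more compounds than are shown below. What is called first, only, known or untested is meant among the compounds shown, and "the series" means these compounds.

The measured compounds, in an in vitro functional assay on Sf9 cells for antagonist activity at histamine H2 receptor (Homo sapiens); a lower number here means a less potent compound, a higher number a more potent compound, by a factor of ten per unit of this negative logarithm:
compound 1, `N#C/N=C(\NCCCCc1ccccc1)NCCCCc1c[nH]cn1`, gives 5.03.
compound 2, `CCN/C(=N\C#N)NCCCCc1c[nH]cn1`, gives < 5, which is a limit of the assay and not a number.
compound 3, `N#C/N=C(/NCCCCCc1c[nH]cn1)NCCCc1ccccc1`, gives 5.28.

Compound 1 and compound 3 are built from the same atoms joined differently; the difference between the two cores is not broken down here. In this assay compound 3 stands highest of the two numbers, and its nearest neighbour is compound 1, a gap that lies within the usual scatter. Compound 2 sits at the floor of the assay (the limit of < 5 in this assay, at which 1 of the 3 values shown sits).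

One change recurs. From compound 1 to compound 2 it is hydrogen in place of phenethyl on a saturated chain carbon, two bonds along the chain from an amine nitrogen, and the step was a number at least 0.03 log units lower from compound 1 to compound 2 (that floor lies within the scatter). From compound 3 to the unmeasured compound 4, `CN/C(=N\C#N)NCCCCCc1c[nH]cn1`, it is hydrogen in place of phenethyl on a saturated chain carbon bound to an amine nitrogen. The two are the same kind of change, not the same: in compound 1 the phenethyl leaves a saturated chain carbon two bonds along the chain from an amine nitrogen, whereas in compound 3 it leaves a saturated chain carbon bound to an amine nitrogen.

On the strength of compound 1 and the step of a number at least 0.03 log units lower from compound 1 to compound 2 (that floor lies within the scatter), compound 4 is expected to lose potency by about a number 0.38 log units lower from compound 3 to compound 4 (beyond the scatter) in this assay. Compound 4 is therefore estimated at 4.9, between 4.4 and 5.4, with a real chance that only a limit is reported.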

Compound 4, negative logarithm of the antagonist equilibrium constant: 5.66
Compound 4: the middle estimate sits 0.76 log units below what was measured; measured number outside the range, above it.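

In this assay, hydrogen in place of phenethyl on a saturated chain carbon bound to an amine nitrogen did not cost potency on the core of compound 3; the step was a number 0.38 log units higher from compound 3 to compound 4 (beyond the scatter). Set beside the earlier case, this result does not show whether the change carries from one core to the other with the same effect: the same change on two cores in this assay, a number at least 0.03 log units lower (that floor lies within the scatter) from compound 1 to compound 2 and a number 0.38 log units higher (beyond the scatter) from compound 3 to compound 4; the limit leaves it open whether they differ Compound 2 gives < 5, which is a limit of the assay and not a number, so the size of the change on the core of compound 1 stays unknown, and there the phenethyl also leaves a different place, a saturated chain carbon two bonds along the chain from an amine nitrogen.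

The compounds shown leave open how potency changes between the two extremes on the core of compound 3, for instance with a propyl group, a benzyl group or a longer chain ending in a phenyl ring in place of phenethyl. They also leave open whether the step of a number at least 0.03 log units lower from compound 1 to compound 2 (that floor lies within the scatter) would resolve into a measured loss or gain on a more sensitive reading.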